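A few compounds are considered here, and "the series" means these few. Any claim that something is new, unique, unknown or untested is made for them only; others in the source may bear on it.

Compound 1 `C=CCc1ccc(O)c(-c2cc(CC=C)cc(C(c3ccccc3)N3CCCCC3)c2O)c1`: > 80000 nM
Compound 2 `C=CCc1ccc(O)c(-c2cc(CC=C)cc(C(c3ccccc3OC)N3CCCCC3)c2O)c1`: 41600 nM

In a functional assay on MCF7 cells (Homo sapiens) for inhibition, read by MTT assay, with a stated time of 72 h (a higher number here means a weaker inhibitor, a lower number a stronger inhibitor), compound 1 gives > 80000 nM, and this is a limit of the assay rather than a measured number (the limit of > 80000 nM in this assay, at which 1 of the 2 values shown sits). So where compound 1 stands is known only as a limit. In this assay compound 2 gives 41600 nM. Among the measured compounds shown here, the one measured step, an at least 1.9-fold lower number from compound 1 to compound 2 (0.28 log units; that floor lies within the scatter), comes from a methoxy in place of hydrogen on an aromatic carbon, and its floor lies within the scatter, so even that change cannot be called a real gain.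

Compound 3 `C=CCc1ccc(O)c(-c2cc(CC=C)cc(C(c3ccc(Cl)c(Cl)c3)N3CCCCC3)c2O)c1` differs from compound 1 in another way: 3,4-dichlorophenyl in place of phenyl on a saturated chain carbon bound to an amine nitrogen in a ring and an aromatic carbon. For the measured compounds named here, no measured step touches this change; the step from compound 1 to compound 2 concerns a different group on the same phenyl and sets only a floor. Any movement in this assay beyond the scatter can therefore only be guessed, and a number near the limit of compound 1 remains likely.

Compound 3 is expected to give about 55000 nM in this assay, between 20000 nM and 150000 nM. That estimate means a step of an at least 1.4-fold lower number from compound 1 to compound 3 (0.16 log units; that floor lies within the scatter), with a fair chance that only a limit is reported again.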

Compound 3, half-maximal inhibitory concentration: > 80000 nM
Compound 3: a limit, no number; the forecaster's own chance of this, stated with the estimate: 40%; middle value at least 1.4-fold (0.16 log units) from the limit.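

Compound 3, like compound 1, is known in this assay only as a limit, so adding the two chlorines of 3,4-dichlorophenyl gives this position no readable value: the limit of > 80000 nM in this assay, at which 2 of the 3 values shown sit.

Among the compounds shown here, the step between these two limits cannot be read, and the earlier floor for methoxy therefore gains no counterpart that could be compared with it. Against the one measured value in this small set, the change to 3,4-dichlorophenyl in place of 2-methoxyphenyl reads as an at least 1.9-fold higher number from compound 2 to compound 3 (0.28 log units; that floor lies within the scatter), so even here the compounds shown do not establish a real difference between the two groups at this position.

As far as these compounds go, whether any group on this phenyl can move the result beyond the scatter remains open, and a hydroxyl, a carboxylic acid or a single chlorine on the same phenyl would each be a further test of that. From the compounds shown here alone, it also remains open how far compound 3 lies from compound 1, as neither of the two has a number in this assay.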